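A Chloro Substituent on the Phenyl Ring of Compound 2

The source may report more compounds than this note shows. Statements on the series, on what has been measured and on what is new or still open speak of the compounds shown alone.

Of the compounds shown here, three sharing one core have been measured in an assay on isolated protein for inhibition of protein tyrosine phosphatase type IVA 3 (Homo sapiens), tested at 5 ug/mL; on this read-out higher numbers stand for more inhibition at the one concentration tested (going by the name of the read-out) and lower numbers for less inhibition. Compound 1 `O=C1NC(=S)S/C1=C\C=C\c1cc(Br)ccc1OCc1ccccc1Br` gives 40.3%, compound 2 `O=C1NC(=S)S/C1=C\C=C\c1ccccc1` gives 37.4%, and compound 3 `O=C1NC(=S)S/C1=C\C=C\c1ccccc1OS(=O)(=O)c1ccccc1` gives 64.2%. On these numbers compound 2 stands lowest of the three: the number for compound 1 lies within the usual scatter of it, so no order between compound 1 and compound 2 can be claimed, whereas compound 3 lies beyond the scatter and is the only one that clearly separates from compound 2.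

Compound 4 `O=C1NC(=S)S/C1=C\C=C\c1ccccc1Cl` has not yet been measured in this assay. It differs from compound 2 in one place: chloro in place of hydrogen on an aromatic carbon.

Within the data shown here, no measured step of this kind is available, so the size of the change must be judged from the three numbers alone. Compound 1, which carries a bromine on its ring and a bulkier group on an aromatic carbon, gives 40.3%, a number within the scatter of compound 2. A single chloro in place of hydrogen is therefore expected to move the number little, with a step of a number 4.6 percentage points higher from compound 2 to compound 4 (within the scatter) estimated to fall within the scatter. For compound 4 an inhibition of 42% is estimated, with a range from 28% to 58%.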

Compound 4, a percentage reported as inhibition, at one concentration (the size of the read-out at that concentration, not a potency): 53.9%
Compound 4: middle estimate off by 11.9 percentage points, on the low side; the range from low to high includes it.
By their numbers in this assay, from the lowest: compounds 2 and 1 (each within the scatter of the next); then compound 4; then compound 3.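

In this assay, chloro in place of hydrogen on an aromatic carbon, ortho to a large group, gives a step of a number 16.5 percentage points higher from compound 2 to compound 4 (beyond the scatter). Among these compounds, this is the first single change whose effect can be read on its own, and it shows that this position is not indifferent: one chlorine atom, entering with no ring, no hydrogen-bond donors or acceptors and no net charge, is enough to separate compound 4 from compound 2, which the earlier compounds, differing from compound 2 in more than one place, could not show. Nothing among the data given here accounts for the size or direction of this step, so no reason for it can be offered.

What stays open is whether the step is particular to chloro, since the compounds shown do not tell how a fluoro, a methyl, a methoxy, an amine or a carboxylic acid would read on the same aromatic carbon. They also leave open whether chloro on another carbon of the ring would give a step of similar size, and so whether the position or the group matters more.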